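A few compounds are considered here, and "the series" means these few. Any claim that something is new, unique, unknown or untested is made for them only; others in the source may bear on it.

Measured compounds in a functional assay on A549 cells (Homo sapiens) for inhibition, read by CCK-8 assay, with a stated time of 72 h, tested at 2 uM; on this read-out lower numbers stand for less inhibition of growth and higher numbers for more inhibition of growth at the one concentration tested:

compound 1, `Nc1ccccc1NC(=O)c1ccc(CSc2ccc(Br)cc2)cc1` — 33.2%
compound 2, `Nc1ccccc1NC(=O)/C=C/c1ccc(CSc2cccc(F)c2)cc1` — 50.7%
compound 3, `CC(C)(C)c1ccc(SCc2ccc(/C=C/C(=O)Nc3ccccc3N)cc2)cc1` — 71.5%

Compound 1 stands lowest of the three numbers in this assay. Its nearest neighbour is compound 2, whose value is higher by a margin beyond the scatter, and compound 3 lies further still above it, also beyond the scatter.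

The next compound, compound 4, `Cc1cc(C)cc(SCc2ccc(C(=O)Nc3ccccc3N)cc2)c1`, differs from compound 1 only on the sulfur: 3,5-dimethylphenyl in place of 4-bromophenyl on a sulfur.

For the measured compounds named here, only one measured step changes the aryl group on the sulfur, and it sits on a different shared core, the one of compound 2 and compound 3: a number 20.8 percentage points higher from compound 2 to compound 3 (beyond the scatter). There a larger alkyl-bearing phenyl in place of a halogen-bearing phenyl went with a modest rise. The change from compound 1 to compound 4 is of the same kind, so a rise of similar or somewhat smaller size is expected, with wide uncertainty because the core differs and a single step is a thin basis.

For compound 4 the expected value in this assay is 45%, in the range 25% to 65%, which would mean a step of a number 11.8 percentage points higher from compound 1 to compound 4 (beyond the scatter).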

Compound 4, percent growth inhibition at one concentration: 33.3%
For compound 4 the middle estimate is 11.7 percentage points above the measured one, and the stated range covers the measured number.
By their numbers in this assay, from the lowest: compounds 1 and 4 (each within the scatter of the next); then compound 2; then compound 3.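

On the core of compound 1, 3,5-dimethylphenyl in place of 4-bromophenyl on a sulfur gives a number 0.1 percentage points higher from compound 1 to compound 4 (within the scatter) in this assay. For the compounds shown here, the only earlier change of the aryl group at this place, on the core of compound 2, gave a number 20.8 percentage points higher from compound 2 to compound 3 (beyond the scatter), so a change of aryl group on the sulfur does not bring a step beyond the scatter in every case, although the two steps differ in both the groups exchanged and the core. Nothing available accounts for the difference between these two steps.

From the compounds shown here alone, whether 4-(tert-butyl)phenyl on the sulfur would also raise the number on the core of compound 1 remains open. Also open, going by these compounds, is how an amine or a carboxylic acid on the aryl group would behave on either core.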